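Chloro on the piperazine aryl of the oxazole carboxamide series

The source may report more compounds than this note shows. Statements on the series, on what has been measured and on what is new or still open speak of the compounds shown alone.

Compound 2 `Cc1nc(-c2ccccc2)c(C(=O)N2CCN(c3ccccc3)CC2)o1` gives 9.63 ug/mL in a toxicity assay on HUVEC cells (Homo sapiens) for inhibition (a higher number here means a weaker inhibitor of growth, a lower number a stronger inhibitor of growth), the highest number among the measured compounds, so the weakest inhibitor of growth measured so far. Compound 1 `Cc1nc(-c2cccc(F)c2)c(C(=O)N2CCN(c3cc(Cl)cc(Cl)c3)CC2)o1` gives 0.134 ug/mL in this assay, and compound 3 `COc1cc(OC)cc(N2CCN(C(=O)c3oc(C)nc3-c3ccccc3F)CC2)c1` gives 0.118 ug/mL; both lie far below compound 2, beyond the scatter, and both carry a substituted aryl on the piperazine together with a fluoro on the oxazole phenyl.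

Compound 4 `Cc1nc(-c2ccccc2)c(C(=O)N2CCN(c3cccc(Cl)c3)CC2)o1` differs from compound 2 in one place: chloro in place of hydrogen on an aromatic carbon, on an aromatic carbon of a six-membered aromatic ring of carbon only, meta to a large group. Within the data shown here, no measured pair shows this single change on its own. Given that compound 1 and compound 3 sit so far below compound 2 while carrying substituted piperazine aryls, the expected step is a 6.4-fold lower number from compound 2 to compound 4 (0.81 log units; beyond the scatter), which would run downward beyond the scatter without reaching compound 1. Compound 4 is therefore estimated at 1.5 ug/mL, within 0.4 ug/mL to 5 ug/mL.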

Compound 4, concentration for 50% growth inhibition: 0.463 ug/mL
Compound 4: middle estimate off by 3.2-fold (0.51 log units), on the high side, and the stated range covers the measured number.
By their numbers in this assay, from the lowest: compounds 3 and 1 (each within the scatter of the next); then compound 4; then compound 2.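

In this assay, chloro in place of hydrogen on the piperazine aryl is enough on its own to give a large change, a 21-fold lower number from compound 2 to compound 4 (1.32 log units; beyond the scatter), with nothing else in the structure altered. The earlier compounds shown here showed a substituted piperazine aryl only together with a fluoro on the oxazole phenyl, whereas this pair isolates phenyl to 3-chlorophenyl, on an aromatic carbon meta to a large group. Nothing available explains why this single chloro has so large an effect on growth inhibition.

As far as these compounds go, whether a nitrile or an amine on the same aromatic carbon would give a step of similar size remains open. Also open, from the compounds shown here alone, are what a fluoro on the oxazole phenyl contributes on its own and whether a second chloro on the piperazine aryl adds to the step.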